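The source may report more compounds than this note shows. Statements on the series, on what has been measured and on what is new or still open speak of the compounds shown alone.

Measured compounds:
- compound 1, `Nc1sc(-c2ccc(Cl)cc2)c(-c2ccc(Cl)cc2)c1C(=O)N1CCCCC1=O`, gives 4940 nM in a functional assay on PC-3 cells (Homo sapiens) for inhibition, read by sulforhodamine B assay, with a stated time of 72 h; on this read-out higher numbers stand for weaker inhibition and lower numbers for stronger inhibition
- compound 2, `Nc1sc(-c2ccc(Cl)cc2)c(-c2ccc(Cl)cc2)c1C(=O)N1CCC(=O)CC1=O`, gives 9230 nM in this assay

Compound 1 has the lowest of the two numbers, but the step of a 1.9-fold higher number from compound 1 to compound 2 (0.27 log units; within the scatter) lies within the usual scatter, so the two compounds cannot be told apart on this assay. Compound 3, `Nc1sc(-c2ccc(Cl)cc2)c(-c2ccc(Cl)cc2)c1C(=O)NCc1ccccc1`, has not been measured. It differs from compound 1 in one place: benzylamino in place of 2-oxopiperidin-1-yl on a carbonyl carbon. Within the data shown here, the only measured step, the one from compound 1 to compound 2, alters a group on the six-membered non-aromatic ring and keeps that ring; it does not replace the ring by a benzylamino group, so it does not bear directly on the change to compound 3. Among the measured compounds shown here, with no comparable step to go on, there is no basis for expecting a step beyond the scatter in either direction in this assay, and the estimate must carry a wide range. Compound 3 is therefore expected to show 5000 nM, with a range from 1500 nM to 20000 nM, which means an expected step of a 1.0-fold higher number from compound 1 to compound 3 (0.01 log units; within the scatter).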

Compound 3, half-maximal inhibitory concentration: 31800 nM
The estimate for compound 3 lay 6.4-fold (0.80 log units) below the measured number; the whole stated range lies below it.
By their numbers in this assay, from the lowest: compounds 1 and 2 (each within the scatter of the next); then compound 3.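

In this assay, the position on the carbonyl carbon turns out to be sensitive to the group it carries: the step is a 6.4-fold higher number from compound 1 to compound 3 (0.81 log units; beyond the scatter), and against the other ring compound it is a 3.4-fold higher number from compound 2 to compound 3 (0.54 log units; beyond the scatter), both towards weaker inhibition. The earlier pair could not show this, as the added ring carbonyl of the 2,4-dioxopiperidin-1-yl group left compound 2 within the scatter of compound 1, whereas giving up the six-membered non-aromatic ring for benzylamino moves the number beyond the scatter. This change alters several things at once, swapping that ring and its carbonyl for a six-membered aromatic ring and adding an amide hydrogen, and no measurement here explains the loss.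

The compounds shown do not separate these features, so it remains open which of them accounts for the step. A piperidin-1-yl group, which keeps the ring without its carbonyl, and a benzyl(methyl)amino group, which keeps the benzyl without the amide hydrogen, would each pull these features apart.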